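Ethoxy to Propoxy: An Expected Small Step in Clearance

The source may report more compounds than this note shows. Statements on the series, on what has been measured and on what is new or still open speak of the compounds shown alone.

In an ADME assay on microsomes from liver (Mus musculus) for metabolic stability; a higher number here means faster removal of the compound, a lower number slower removal:
- Compound 1 `CCO[C@@H]1O[C@H](CNC(=O)c2ccc(S(N)(=O)=O)cc2)[C@@H](O)[C@H](O)[C@H]1O`: 1.54 mL/min/kg
- Compound 2 `CCO[C@@H]1O[C@H](CNC(=O)c2ccc(S(N)(=O)=O)cc2)[C@H](O)[C@H](O)[C@H]1O`: 1.5 mL/min/kg
- Compound 3 `CCCO[C@@H]1O[C@H](CNC(=O)c2ccc(S(N)(=O)=O)cc2)[C@H](O)[C@H](O)[C@H]1O`: not yet measured

Compound 2 cannot be told apart from compound 1 on these numbers. Going by the values given here, the only measured step is a 1.0-fold lower number from compound 1 to compound 2 (0.01 log units; within the scatter). It bears only loosely on what follows, given (the fact that compounds 1 and 2 differ only in the configuration as drawn). Compound 3 differs by methyl in place of hydrogen on a saturated chain carbon, two bonds along the chain from an oxygen on a saturated carbon, which reads ethoxy to propoxy. Among the compounds with values here, with compound 2 at 1.5 mL/min/kg and no measured step touching this chain, a small upward step or none beyond the scatter is expected in this assay. The expected step is a 1.2-fold higher number from compound 2 to compound 3 (0.08 log units; within the scatter). For compound 3 the estimated value is 1.8 mL/min/kg, with an expected range from 1.1 mL/min/kg to 3.5 mL/min/kg.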

Compound 3, clearance: 1.38 mL/min/kg
Compound 3: the middle estimate sits 1.3-fold (0.12 log units) above what was measured; the measured number falls inside the stated range.
By their numbers in this assay, from the lowest: compounds 3, 2 and 1 (each within the scatter of the next).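

Compounds 1 and 2 both carry ethoxy, so they said nothing about this chain. In this assay, the change from ethoxy to propoxy gives a 1.1-fold lower number from compound 2 to compound 3 (0.04 log units; within the scatter). This single added methyl therefore causes no change that can be told from the scatter, and nothing given here bears on why.

As far as these compounds go, whether a longer chain such as butoxy would behave the same way stays open. So does the outcome of replacing propoxy with a group of a different kind, such as an amine or a carboxylic acid.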